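Bromo in Place of Chloro: An Expected Small Step

The compounds below may be only part of what the source reports. "The series", "measured", "known", "first", "only" and "open" are said of these compounds alone.

In a functional assay on HepG2 cells (Homo sapiens) for antiproliferative activity, read by MTT assay, with a stated time of 24 h (on this read-out lower numbers stand for stronger inhibition and higher numbers for weaker inhibition), compound 1 `Cc1ccc(-c2nn(-c3ccccc3)cc2-c2nc3ccccc3n2S(=O)(=O)c2ccc(Br)cc2)cc1` records 3040 nM as its value. Compound 2 `O=S(=O)(c1ccc(Cl)cc1)n1c(-c2cn(-c3ccccc3)nc2-c2ccc(C(F)(F)F)cc2)nc2ccccc21` records 3930 nM and so stands within the scatter of compound 1. Compound 3 `O=S(=O)(c1ccc(Br)cc1)n1c(-c2cn(-c3ccccc3)nc2-c2ccc(C(F)(F)F)cc2)nc2ccccc21` differs from compound 2 only by bromo in place of chloro on an aromatic carbon. Going by the values given here, no measured pair shows this change alone, so no step beyond the scatter is expected in this assay for it. The estimated change (a 1.1-fold lower number from compound 2 to compound 3 (0.05 log units; within the scatter)) stays within that scatter. Compound 3 is expected at 3500 nM (estimated range 1700 nM to 7000 nM).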

Compound 3, half-maximal inhibitory concentration: 2160 nM
Compound 3: middle estimate off by 1.6-fold (0.21 log units), on the high side; measured number inside the range.
By their numbers in this assay, from the lowest: compounds 3, 1 and 2 (each within the scatter of the next).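

With compound 3, the change from 4-chlorophenyl to 4-bromophenyl has a measured pair in this assay, and it reads a 1.8-fold lower number from compound 2 to compound 3 (0.26 log units; within the scatter) with no step beyond the scatter at this position. Going by these compounds alone, compound 3 also gives a first reading of trifluoromethyl in place of methyl on an aromatic carbon, a 1.4-fold lower number from compound 1 to compound 3 (0.15 log units; within the scatter) and again within the scatter. Nothing at hand explains the size of either step.

Still open, going by these compounds, is whether a very different group on the same aromatic carbon, such as an amine or a carboxylic acid, would move the number beyond the scatter.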